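Changing the aromatic group on the sulfur side chain

The source may report more compounds than this note shows. Statements on the series, on what has been measured and on what is new or still open speak of the compounds shown alone.

Measured in a functional assay on PC-3 cells (Homo sapiens) for cytotoxicity, read by MTT assay; a lower number here means a stronger inhibitor, a higher number a weaker inhibitor:
Compound 1 `COc1ccc2cc([C@H](C)c3nnc(SCc4ccc(C)cc4)n3-c3ccc(F)cc3)ccc2c1`: 229000 nM
Compound 2 `COc1ccc(CSc2nnc([C@@H](C)c3ccc4cc(OC)ccc4c3)n2-c2ccc(F)cc2)cc1`: 400000 nM
Compound 3 `COc1ccc2cc([C@H](C)c3nnc(SCc4c(Cl)cccc4Cl)n3-c3ccc(F)cc3)ccc2c1`: 216000 nM

In this assay compound 3 gives 216000 nM, which lies within the scatter of the values of the other two compounds, so the three cannot be ranked. Compound 4 `COc1ccc2cc([C@H](C)c3nnc(SCc4c(C)cc(C)cc4C)n3-c3ccc(F)cc3)ccc2c1` has not yet been measured. It differs from compound 3 in a single group, with 2,4,6-trimethylphenyl in place of 2,6-dichlorophenyl on a saturated chain carbon bound to a sulfur.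

The three measured compounds differ from one another only in the group on that same carbon, so all their steps bear on this change. There is a 1.7-fold higher number from compound 1 to compound 2 (0.24 log units; within the scatter), then a 1.1-fold lower number from compound 1 to compound 3 (0.03 log units; within the scatter), and finally a 1.9-fold lower number from compound 2 to compound 3 (0.27 log units; within the scatter). All three steps are small, and none leaves the scatter. None of these compounds carries the 2,4,6-trimethylphenyl group, so the evidence is thin and an unexpected result remains possible. Even so, no step beyond the scatter is expected in this assay, and no direction can be favoured. The expected change is a 1.2-fold higher number from compound 3 to compound 4 (0.06 log units; within the scatter). For compound 4 the estimated value is 250000 nM, with an expected range from 120000 nM to 500000 nM.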

Compound 4, half-maximal inhibitory concentration: 43300 nM
Estimate against measurement, compound 4: 5.8-fold (0.76 log units) above; measured number below the stated range.
By their numbers in this assay, from the lowest: compound 4; then compounds 3, 1 and 2 (each within the scatter of the next).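

Earlier steps on this saturated chain carbon bound to a sulfur all stayed within the scatter in this assay, so the position could have seemed indifferent to the aromatic group placed there. The 2,4,6-trimethylphenyl group changes that picture, giving a 5.0-fold lower number from compound 3 to compound 4 (0.70 log units; beyond the scatter) and a 5.3-fold lower number from compound 1 to compound 4 (0.72 log units; beyond the scatter) as well as a 9.2-fold lower number from compound 2 to compound 4 (0.97 log units; beyond the scatter) in the same assay, which makes compound 4 the strongest inhibitor of the four even though compounds 1, 2 and 3 cannot be ranked against one another. The 2,6-dichlorophenyl and 2,4,6-trimethylphenyl groups each hold one six-membered aromatic ring of carbon only, with no hydrogen-bond donors or acceptors and no net charge, so these counts do not separate them and the visible difference is that methyl groups stand where the chlorine atoms stood, with one more methyl added.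

As far as these compounds go, it remains open whether all three methyl groups are needed, as 2,6-dimethylphenyl would show, and how a ring bearing an amine or a carboxylic acid would behave on this carbon. Nothing shown here gives a measured reason for the step from 2,6-dichlorophenyl to 2,4,6-trimethylphenyl.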